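Fluorine Swap on the Phenyl Carried onto a Second Core

The compounds below may be only part of what the source reports. "The series", "measured", "known", "first", "only" and "open" are said of these compounds alone.

Measured compounds:
compound 1, `C=C1C(=O)[C@]23C[C@@]1(O)CC[C@H]2c1ccc(O)c(C)c1[C@@H]3Cn1cc(-c2ccccc2)nn1`, 750 nM
compound 2, `C=C1C(=O)[C@]23C[C@@]1(O)CC[C@H]2c1ccc(O)c(C)c1[C@@H]3Cn1cc(-c2ccc(F)cc2)nn1`, 660 nM
compound 3, `C=C1C[C@]23C[C@@]1(O)CC[C@H]2c1cc(Br)c(O)c(C)c1[C@@H]3Cn1cc(-c2ccccc2)nn1`, a limit of > 20000 nM

In a functional assay on HL-60 cells (Homo sapiens) for cytotoxicity, read by MTT assay, with a stated time of 4 days (on this read-out higher numbers stand for weaker inhibition and lower numbers for stronger inhibition), compound 1 gives 750 nM and compound 2 gives 660 nM. The two are related by fluoro in place of hydrogen on an aromatic carbon, and that change made a 1.1-fold lower number from compound 1 to compound 2 (0.06 log units; within the scatter).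

Compound 3 belongs to a different core. How that core differs from the core of compound 1 is not broken down here. For compound 3 this assay reports only a limit, > 20000 nM, as noted in the limit of > 20000 nM in this assay, at which 1 of the 3 values shown sits.

Compound 4, `C=C1C[C@]23C[C@@]1(O)CC[C@H]2c1cc(Br)c(O)c(C)c1[C@@H]3Cn1cc(-c2ccc(F)cc2)nn1`, is the unmeasured partner of compound 3. It differs from compound 3 by fluoro in place of hydrogen on an aromatic carbon, which is the same change as that from compound 1 to compound 2. On the core of compound 1 this change gave a step within the scatter, so no shift of any real size is expected from it on the core of compound 3 either; the step expected is a step that the limit leaves unreadable from compound 3 to compound 4, and this rests on the earlier step of a 1.1-fold lower number from compound 1 to compound 2 (0.06 log units; within the scatter) being within the scatter while compound 3 sits at the limit.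

The estimate for compound 4 in this assay is therefore 25000 nM, with a range from 8000 nM to 60000 nM, and the expectation is that this assay again reports only a limit for compound 4 rather than a number.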

Compound 4, half-maximal inhibitory concentration: 6600 nM
Compound 4: the middle estimate sits 3.8-fold (0.58 log units) above what was measured; the whole stated range lies above it.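

In this assay the change from phenyl to 4-fluorophenyl on the second core gave an at least 3.0-fold lower number from compound 3 to compound 4 (0.48 log units; beyond the scatter) and so, unlike the same change on the core of compound 1, produced a step beyond the scatter on this core. This does not establish that the change behaves differently on the two cores, and a comparison of the two steps remains unsettled: the same change on two cores in this assay, a 1.1-fold lower number (0.06 log units; within the scatter) from compound 1 to compound 2 and an at least 3.0-fold lower number (0.48 log units; beyond the scatter) from compound 3 to compound 4; the limit leaves it open whether they differ. The step from the second core also has an open size, as compound 3 stands at a limit and not at a number: the limit of > 20000 nM in this assay, at which 1 of the 4 values shown sits. Going by these compounds alone, each core contributes only a single pair, so the result is one observation per core and not a rule for carrying this change across the series.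

The compounds shown carry only hydrogen or fluoro on the aromatic carbon para to the large group, which leaves open how a chloro, a methoxy or an amine at that place would read on either core. They also leave open which part of the difference between the two cores goes with the step seen on the second core, and whether a number for compound 3 would set the two steps apart.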